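This account rests on a few compounds, and the source may have more. Where it says the series, first, only, none or still open, it means among the compounds named here.

Measured so far:
compound 1 `O=C(O)Cc1sc(C(c2ccc(F)cc2)c2ccc(F)cc2)nc1-c1ccnc(N2CCCC2)c1`: 80%
compound 2 `O=C(O)Cc1sc(C(c2ccccc2)c2ccccc2)nc1-c1ccc(F)c(F)c1`: 80%

In an in vitro functional assay on HEK285-7 cells for antagonist activity at prostaglandin D2 receptor 2 (Homo sapiens), read by BRET and beta-arrestin recruitment (on this read-out higher numbers stand for larger maximal responses and lower numbers for smaller maximal responses), compound 1 gives 80% and compound 2 gives 80%; compound 1 thus stands level with compound 2, the two values lying within the usual scatter, so no order between them can be read.

Compound 3 `O=C(O)Cc1sc(C(c2ccc(F)cc2)c2ccc(F)cc2)nc1-c1ccco1` differs from compound 1 in one place: furan-2-yl in place of 2-(pyrrolidin-1-yl)pyridin-4-yl on an aromatic carbon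

Within the data shown here, no step between two measured compounds is available to size this change, and the two measured values give no trend. The step of a number 8 percentage points lower from compound 1 to compound 3 (within the scatter) is expected to be small and, if anything, downward, likely not beyond the scatter. Compound 3 is estimated at 72%, with a range from 45% to 95%.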

Compound 3, largest response reached (reported as efficacy), in percent of the reference or control that the assay uses: 80%
Compound 3: middle estimate off by 8 percentage points, on the low side, and the stated range covers the measured number.
By their numbers in this assay, from the lowest: compounds 1, 2 and 3 (each within the scatter of the next).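

In this assay, furan-2-yl in place of 2-(pyrrolidin-1-yl)pyridin-4-yl gives no change at the digits printed from compound 1 to compound 3 (within the scatter) on this aromatic carbon next to the ring nitrogen. This first one-place step in the series shows that the maximal response holds across these two groups, although the entering group has fewer heavy atoms and lacks the non-aromatic ring. Nothing measured here gives a reason for this result. Still open, going by these compounds, is whether a non-aromatic group at this carbon, such as a methyl or a morpholine, would keep this response.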